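Removing a Methoxy Group and Expected Cell Tolerance

This account rests on a few compounds, and the source may have more. Where it says the series, first, only, none or still open, it means among the compounds named here.

Three closely related compounds have been tested for how much of them cultured human cells tolerate. Compound 1 `COc1ccc(-n2c(=O)n(Cc3cc4cc(Cl)ccc4n3CCCC#N)c3cnccc32)cc1OC` carries a 3,4-dimethoxyphenyl group on the shared core. In an ADME assay on HeLa cells (Homo sapiens) for cytotoxicity, read by ATP content, with a stated time of 3 days (a higher number here means that more compound is tolerated, a lower number that less compound is tolerated), compound 1 gives > 50000 nM, which is a limit of the assay rather than a measured number. Compound 2 `N#CCCCn1c(Cn2c(=O)n(C3CC3)c3ccncc32)nc2nc(Cl)ccc21` also reaches only a limit in this assay, namely > 50000 nM. Compound 3 `CC1(n2c(=O)n(Cc3cc4cc(Cl)ccc4n3CCCS(C)(=O)=O)c3cnccc32)CC1` likewise stops at a limit in this assay, giving > 50000 nM. Compound 1 therefore stands where every measured compound stands, at the limit of > 50000 nM in this assay, at which 3 of the 3 values shown sit. For the measured compounds named here, no two measured compounds differ in just one place, so no measured step is available to learn from.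

Compound 4 `COc1ccc(-n2c(=O)n(Cc3cc4cc(Cl)ccc4n3CCCC#N)c3cnccc32)cc1` is the one not yet measured. It differs from compound 1 by hydrogen in place of methoxy on an aromatic carbon. Cut one bond further out, the change reads 3,4-dimethoxyphenyl to 4-methoxyphenyl. Going by the values given here, no shift beyond the usual scatter is expected in this assay because all values measured so far sit at the limit of > 50000 nM in this assay, at which 3 of the 3 values shown sit, and the step is estimated as a step that the limit leaves unreadable from compound 1 to compound 4. Compound 4 is thus expected to give about 60000 nM in this assay, most likely between 25000 nM and 150000 nM, and probably to be reported again only as a limit.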

Compound 4, half-maximal cytotoxic concentration: > 50000 nM
Compound 4: no number, only a limit; the forecaster's own chance of this, stated with the estimate: 80%; the middle value is on the limit's open side.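

Compound 1 and compound 4 both stop at a limit of the assay rather than at a number, so no step can be read between them: the limit of > 50000 nM in this assay, at which 4 of the 4 values shown sit.

In this assay the compounds shown leave open how much of each is actually tolerated, and whether hydrogen in place of methoxy changes that at all.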